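This account rests on a few compounds, and the source may have more. Where it says the series, first, only, none or still open, it means among the compounds named here.

Measured in a physicochemical assay for lipophilicity, using the shake flask method, in phosphate buffer, measured as octanol-water partition, with a stated time of 30 min, at pH 7.4; a higher number here means a more lipophilic compound, a lower number a more polar compound:
- compound 1 `CN(c1ncco1)c1cnc(NCc2c(F)ccc3c2CCO3)n2cnnc12`: 2.1
- compound 2 `C[C@@H]1CC(=O)N(c2cnc(NCc3c(F)ccc4c3CCO4)n3cnnc23)C1`: 1.8
- compound 3 `CN(c1ccn(C)n1)c1cnc(NCc2c(F)ccc3c2CCO3)n2cnnc12`: 1.8

Compound 3 stands level with compound 2 at the digits shown, and all three values lie within the scatter of one another. In compound 4 `O=C(Nc1cnc(NCc2c(F)ccc3c2CCO3)n2cnnc12)c1cccnc1`, ((pyridin-3-yl)carbonyl)amino takes the place of methyl(1-methyl-1H-pyrazol-3-yl)amino on an aromatic carbon (((pyridin-3-yl)carbonyl)amino in place of methyl(1-methyl-1H-pyrazol-3-yl)amino on an aromatic carbon). Three measured steps change the group at this carbon: a number 0.30 log units lower from compound 1 to compound 2 (within the scatter), a number 0.30 log units lower from compound 1 to compound 3 (within the scatter) and no change at the digits printed from compound 2 to compound 3 (within the scatter). All lie within the scatter, but none brings in the entering group, so this precedent is indirect. Resting on these small steps, no change beyond the scatter is expected in this assay, and the estimated step is a number 0.10 log units higher from compound 3 to compound 4 (within the scatter). The estimate for compound 4 is 1.9, with an expected range of 1.4 to 2.4.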

Compound 4, distribution coefficient: 2
Beside the measured number, compound 4's estimate is 0.10 log units below it; measured number inside the range.
By their numbers in this assay, from the lowest: compounds 2, 3, 4 and 1 (each within the scatter of the next).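

At this aromatic carbon, ((pyridin-3-yl)carbonyl)amino keeps this assay within the scatter of the other groups shown, with a number 0.20 log units higher from compound 3 to compound 4 (within the scatter), a number 0.20 log units higher from compound 2 to compound 4 (within the scatter) and a number 0.10 log units lower from compound 1 to compound 4 (within the scatter). The earlier compounds shown here could not show that a group with a hydrogen-bond donor, a carbonyl and a six-membered aromatic ring gives no step beyond the scatter at this place. Nothing shown accounts for this result. On these data alone, whether an aliphatic amine or a carboxylic acid at this carbon would give a step beyond the scatter remains open.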